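Hydroxy to Methoxy at the Assay Limit

The compounds below may be only part of what the source reports. "The series", "measured", "known", "first", "only" and "open" are said of these compounds alone.

In a functional assay on KB 3-1 cells (Homo sapiens) for inhibition, with a stated time of 72 h (a higher number here means a weaker inhibitor, a lower number a stronger inhibitor), compound 1 (`COc1cc2oc(-c3ccccc3)cc(=O)c2c(OC)c1OC(C)=O`) gives > 100000 nM, which is a limit of the assay and not a number. Compound 2 (`CCCCCCOc1cc2oc(-c3ccccc3)cc(=O)c2c(O)c1OCCCCCC`) also gives only a limit, > 100000 nM. Compound 2 therefore stands at the limit of > 100000 nM in this assay, at which 2 of the 2 values shown sit. Compound 3 (`CCCCCCOc1cc2oc(-c3ccccc3)cc(=O)c2c(OC)c1OCCCCCC`) carries methyl in place of hydrogen on an oxygen on an aromatic ring, taking hydroxy to methoxy: methyl in place of hydrogen on an oxygen on an aromatic ring. Within the data shown here, no measured step covers this change, and the expected step of a number no higher from compound 2 to compound 3 (the limit leaves the size open) is none beyond the scatter. For compound 3 the estimated value is 100000 nM, with an expected range of 30000 nM to 200000 nM.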

Compound 3, half-maximal inhibitory concentration: 44800 nM
Compound 3: middle estimate off by 2.2-fold (0.35 log units), on the high side; measured number inside the range.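

Methyl in place of hydrogen on an oxygen on an aromatic ring brings an at least 2.2-fold lower number from compound 2 to compound 3 (0.34 log units; beyond the scatter) in this assay. With compound 3 at 44800 nM, this position is shown to respond to the change, and the hydroxy to methoxy swap yields the only value in the set that is a number. The true size of the step remains unknown, as the value for compound 2 is a limit of the assay: the limit of > 100000 nM in this assay, at which 2 of the 3 values shown sit.

The compounds shown leave open whether an ethyl group or a longer chain on this oxygen, or an amine in place of the hydroxy, would lower the number further. They also leave open whether the same change would have this effect with other groups on the remaining oxygens.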